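The compounds below may be only part of what the source reports. "The series", "measured", "known", "first", "only" and "open" are said of these compounds alone.

For the measured compounds named here, the three compounds measured so far share one core, carrying an amide on one side and a six-membered aromatic ring of carbon only on the other. Compound 1 `Cc1cccc(-n2cnc3cc(C(=O)N4CC(C)CC(C)C4)ccc32)c1` gives 271 nM in an assay on isolated protein for inhibition of 15-hydroxyprostaglandin dehydrogenase [NAD(+)] (Homo sapiens), read by fluorescence, with a stated time of 15 min; a higher number here means a weaker inhibitor, a lower number a stronger inhibitor. Compound 2 `Cc1cccc(-n2cnc3cc(C(=O)N4CCCC(c5ccccc5)C4)ccc32)c1` gives 429 nM in this assay. Compound 3 `O=C(c1ccc2c(c1)ncn2-c1ccccc1)N1CCCCC1`, with no substituent on either outer ring, gives 22 nM in this assay, the lowest of the three numbers; its distances to compound 1 and to compound 2 both lie beyond the scatter, so it is the strongest inhibitor of the set.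

Compound 4 `O=C(c1ccc2c(c1)ncn2-c1cccc(C(F)(F)F)c1)N1CCCCC1` is not yet measured. It differs from compound 3 in one place: trifluoromethyl in place of hydrogen on an aromatic carbon, sitting meta to a large group on the aromatic ring attached to the core. Going by the values given here, no measured pair shows this change on its own, and compounds 1 and 2 differ from compound 3 on both outer rings at once, so their numbers cannot be split into separate steps. The step that this estimate means, a 2.0-fold higher number from compound 3 to compound 4 (0.31 log units; beyond the scatter), is expected to be modest, leaning toward a weaker inhibitor. Compound 4 is estimated at 45 nM in this assay, with a range from 15 nM to 150 nM.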

Compound 4, half-maximal inhibitory concentration: 48 nM
The estimate for compound 4 lay 1.1-fold (0.03 log units) below the measured number; the range from low to high includes it.
By their numbers in this assay, from the lowest: compound 3; then compound 4; then compounds 1 and 2 (each within the scatter of the next).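

For the compounds shown here, compound 3 and compound 4 form the first pair in the set that differs in one place only, so the effect of a single change on the aromatic ring attached to the core can now be read on its own. In this assay, trifluoromethyl in place of hydrogen gives a 2.2-fold higher number from compound 3 to compound 4 (0.34 log units; beyond the scatter) and so costs only a modest amount of inhibition, even though a hydrogen atom gives way to a group of 4 heavy atoms. Nothing measured here bears on the reason for this step.

The compounds shown leave open how a fluorine atom, a nitrile or an amine at this same place would compare with trifluoromethyl. They also leave open whether the step would keep its size with a different amide on the other side of the core.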